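Compound 3 to compound 4: cyclopropyl in place of methoxy

The source may report more compounds than this note shows. Statements on the series, on what has been measured and on what is new or still open speak of the compounds shown alone.

Measured in a toxicity assay on microsomes from liver (Homo sapiens) for metabolic stability, read by LC-MS, using NADPH, tested at 1 uM; on this read-out lower numbers stand for slow clearance and higher numbers for fast clearance:
- Compound 1 `C[C@@H]1CN(c2sc(CN(C)C)nc2-c2nc3ccccc3[nH]2)CCN1C(=O)Cn1cnc2cccnc21`: 44 mL.min-1.g-1
- Compound 2 `CCOc1ncc(-c2nc(C(F)(F)F)sc2N2CCN(C(=O)Cn3cnc(C(F)(F)F)n3)[C@H](C)C2)cn1`: < 10 mL.min-1.g-1, a limit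
- Compound 3 `COc1ncc(-c2nc(C(F)(F)F)sc2N2CCN(C(=O)Cn3nc(C)nc3C)[C@H](C)C2)cn1`: < 10 mL.min-1.g-1, a limit

Compound 3 gives only a limit, < 10 mL.min-1.g-1. This places it at the limit of < 10 mL.min-1.g-1 in this assay, at which 2 of the 3 values shown sit.

Compound 4 `Cc1nc(C)n(CC(=O)N2CCN(c3sc(C(F)(F)F)nc3-c3cnc(C4CC4)nc3)C[C@H]2C)n1` carries cyclopropyl in place of the methoxy of compound 3 on an aromatic carbon, para to a large group, taking 2-methoxypyrimidin-5-yl to 2-cyclopropylpyrimidin-5-yl (cyclopropyl in place of methoxy on an aromatic carbon). Within the data shown here, no measured step isolates this change. A small rise in this assay is expected, an at least 1.2-fold higher number from compound 3 to compound 4 (0.07 log units; that floor lies within the scatter). The estimate for compound 4 is 12 mL.min-1.g-1, with an expected range of 6 mL.min-1.g-1 to 25 mL.min-1.g-1.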

Compound 4, intrinsic clearance in microsomes: < 10 mL.min-1.g-1
Compound 4: only a limit was reported; the forecaster's own chance of this, stated with the estimate: 45%; at least 1.2-fold (0.07 log units) between middle value and limit.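

Compound 4 gives < 10 mL.min-1.g-1, a limit. Compound 3 gives < 10 mL.min-1.g-1, also a limit, so no step can be read for this pair. The compounds shown leave open how cyclopropyl and methoxy compare in clearance under that limit.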